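A few compounds are considered here, and "the series" means these few. Any claim that something is new, unique, unknown or untested is made for them only; others in the source may bear on it.

Measured so far:
compound 1, `O=C(O)Cc1ccc(C=C2CCN(C(=O)C(C3CCCCC3)C3CCCCC3)CC2)c(F)c1`: 38 nM
compound 2, `O=C(O)c1ccc(C=C2CCN(C(=O)CC(c3ccccc3)c3ccccc3)CC2)cc1`: 880 nM

Both compounds were tested in an assay on Prostate gland for inhibition of 3-oxo-5-alpha-steroid 4-dehydrogenase 2 (Rattus norvegicus); a higher number here means a weaker inhibitor, a lower number a stronger inhibitor. Compound 1 gives 38 nM, the lower of the two numbers, and compound 2 gives 880 nM, a gap that lies beyond the usual scatter of repeated measurements. Compound 2 differs from compound 1 in more than one place, so these two values say nothing on their own about any single change.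

Compound 3, `O=C(O)c1ccc(C=C2CCN(C(=O)C(C3CCCCC3)C3CCCCC3)CC2)c(F)c1`, has not yet been measured. It differs from compound 1 in one place only: carboxy in place of carboxymethyl on an aromatic carbon. The rest of the molecule, including the fluoro group and the large group on the same ring, is kept.

Among the compounds with values here, since no pair of measured compounds differing only in this way is available, the direction of the step has to be guessed. The expectation here is a modest weakening, with the step from compound 1 to compound 3 estimated at a 2.6-fold higher number from compound 1 to compound 3 (0.42 log units; beyond the scatter), which could still fall within the scatter. Compound 3 is therefore expected to give 100 nM in this assay, with a plausible range from 25 nM to 400 nM.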

Compound 3, half-maximal inhibitory concentration: 3000 nM
The estimate for compound 3 lay 30-fold (1.48 log units) below the measured number, outside the stated range (above it).
By their numbers in this assay, from the lowest: compound 1; then compound 2; then compound 3.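

In this assay, the change from 4-(carboxymethyl)-2-fluorophenyl to 4-carboxy-2-fluorophenyl gives a 79-fold higher number from compound 1 to compound 3 (1.90 log units; beyond the scatter), a large step well beyond the usual scatter. Within the data shown here, this is the first direct reading at this position, and with the fluoro group and the large group kept, it shows that this inhibition depends strongly on which of these two groups sits on the aromatic carbon; carboxymethyl gives the much lower number of the two, so a small edit here is far from neutral. No measurement of any property of these compounds bears on why the step is so large, so its cause remains unknown.

Going by these compounds, two carboxylic acid side chains give only two points, so it remains open whether a longer chain such as carboxyethyl would bring the number lower still or raise it again, and whether a primary amide or a methyl ester could stand in for the acid at this position. On these data alone, it is also open whether a step of this size would recur on a ring without the fluoro group or with a different large group.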